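The compounds below may be only part of what the source reports. "The series", "measured", "known", "first", "only" and "open" are said of these compounds alone.

In a physicochemical assay for solubility, read by spectrophotometry, in phosphate buffer, with a stated time of 2 h, at pH 7.4 (on this read-out higher numbers stand for higher solubility and lower numbers for lower solubility), compound 1 `COc1cccc(CN2C(=O)CN(C(=O)c3cc4cc(OC)ccc4[nH]3)C[C@@H]2COCc2ccccc2)c1` gives 11700 nM. Compound 3 `COc1cccc(CN2C(=O)CN(C(=O)c3cc4cc(OC)ccc4[nH]3)C[C@@H]2CC2CCCCC2)c1` differs from it by cyclohexyl in place of benzyloxy on a saturated chain carbon bound to a saturated ring carbon and gives 21400 nM; the step is a 1.8-fold higher number from compound 1 to compound 3 (0.26 log units; within the scatter). Compound 2 `COc1ccc2[nH]c(C(=O)N3CC(=O)N(Cc4ccccc4)[C@@H](CN4CCC(C)CC4)C3)cc2c1` gives 93100 nM, the highest of the three numbers, and its gaps to compound 3 and to compound 1 both lie beyond the scatter. Compound 4 `COc1ccc2[nH]c(C(=O)N3CC(=O)N(Cc4ccccc4)[C@@H](CN4CC5CCCCC5C4)C3)cc2c1` differs from compound 2 by a group of 9 heavy atoms (8 carbon, 1 nitrogen; one five-membered non-aromatic ring with 1 hetero atom, one six-membered non-aromatic ring of carbon only) in place of a group of 7 heavy atoms (6 carbon, 1 nitrogen; one six-membered non-aromatic ring with 1 hetero atom), on a saturated chain carbon bound to a saturated ring carbon. For the measured compounds named here, no measured pair shows an exchange of this kind: the only step in hand, a 1.8-fold higher number from compound 1 to compound 3 (0.26 log units; within the scatter), concerns a different exchange at the same kind of position and stayed within the scatter. The present change is a larger one, and the number for compound 4 is therefore expected to come out somewhat lower than that of compound 2, with a 2.3-fold lower number from compound 2 to compound 4 (0.37 log units; beyond the scatter) a modest drop that may or may not clear the scatter. Compound 4 is estimated at 40000 nM, with a range from 12000 nM to 130000 nM.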

Compound 4, solubility: 23800 nM
Compound 4: middle estimate off by 1.7-fold (0.23 log units), on the high side; the range from low to high includes it.
By their numbers in this assay, from the lowest: compounds 1, 3 and 4 (each within the scatter of the next, the first and the last beyond it); then compound 2.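

For the compounds shown here, the step of a 3.9-fold lower number from compound 2 to compound 4 (0.59 log units; beyond the scatter) is the first at a saturated chain carbon bound to a saturated ring carbon to lie beyond the scatter, so the read-out in this assay can respond to the group placed there. The two groups have the same counts of hydrogen-bond donors and acceptors and the same lack of net charge, so this step came with no change in those counts, only in heavy atoms and rings. Nothing measured alongside this result accounts for the drop.

This single pair cannot separate the added heavy atoms from the second ring or from the five-membered ring that now carries the nitrogen. As far as these compounds go, how a morpholine, an unsubstituted piperidine or an open-chain diethylamine would read on the same carbon remains open.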